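Moving a trifluoromethyl group around a shared core

The source may report more compounds than this note shows. Statements on the series, on what has been measured and on what is new or still open speak of the compounds shown alone.

Compound 1 `CN(C(=O)NC(=O)c1cccc(C(F)(F)F)c1)c1nc(C(F)(F)F)c(C(=O)N/N=C/c2ccc(C(F)(F)F)cc2)s1` was tested in a functional assay on A549 cells (Homo sapiens) for inhibition, read by MTT assay, with a stated time of 72 h (a higher number here means a weaker inhibitor, a lower number a stronger inhibitor), where compound 1 gives 6.2 ug/mL. Compound 2 `CN(C(=O)NC(=O)c1cccc(C(F)(F)F)c1)c1nc(C(F)(F)F)c(C(=O)N/N=C/c2ccccc2C(F)(F)F)s1` differs from it by 2-(trifluoromethyl)phenyl in place of 4-(trifluoromethyl)phenyl on a carbon with a double bond to nitrogen; in this assay compound 2 gives 12.1 ug/mL, a step of a 2.0-fold higher number from compound 1 to compound 2 (0.29 log units; within the scatter). Compound 3 `CN(C(=O)NC(=O)c1c(F)cccc1F)c1nc(C(F)(F)F)c(C(=O)N/N=C/c2ccc(C(F)(F)F)cc2)s1` carries a different change, (2,6-difluorophenyl in place of 3-(trifluoromethyl)phenyl on a carbonyl carbon), and in this assay compound 3 gives 40.1 ug/mL, a step of a 6.5-fold higher number from compound 1 to compound 3 (0.81 log units; beyond the scatter). Compound 4 `CN(C(=O)NC(=O)c1c(F)cccc1F)c1nc(C(F)(F)F)c(C(=O)N/N=C/c2ccccc2C(F)(F)F)s1` has not yet been measured. It differs from compound 3 by 2-(trifluoromethyl)phenyl in place of 4-(trifluoromethyl)phenyl on a carbon with a double bond to nitrogen, which is the same change that separates compound 1 from compound 2, made at the same place. Because the earlier step was a 2.0-fold higher number from compound 1 to compound 2 (0.29 log units; within the scatter), the step now expected is a 1.9-fold higher number from compound 3 to compound 4 (0.27 log units; within the scatter). The value estimated for compound 4 in this assay is 75 ug/mL, with a range from 35 ug/mL to 160 ug/mL.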

Compound 4, half-maximal inhibitory concentration: 17.9 ug/mL
Compound 4: the middle estimate sits 4.2-fold (0.62 log units) above what was measured; the measured number lies below the stated range.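

In this assay, swapping 4-(trifluoromethyl)phenyl for 2-(trifluoromethyl)phenyl gives a 2.2-fold lower number from compound 3 to compound 4 (0.35 log units; beyond the scatter), so this change does not carry over unaltered between the two cores: the same change on two cores in this assay, a 2.0-fold higher number (0.29 log units; within the scatter) from compound 1 to compound 2 and a 2.2-fold lower number (0.35 log units; beyond the scatter) from compound 3 to compound 4, 4.4-fold (0.64 log units) apart, beyond the scatter of two such steps. The swap from 3-(trifluoromethyl)phenyl to 2,6-difluorophenyl also shifts in size, giving a 1.5-fold higher number from compound 2 to compound 4 (0.17 log units; within the scatter): the same change on two cores in this assay, a 6.5-fold higher number (0.81 log units; beyond the scatter) from compound 1 to compound 3 and a 1.5-fold higher number (0.17 log units; within the scatter) from compound 2 to compound 4, 4.4-fold (0.64 log units) apart, beyond the scatter of two such steps. So among these compounds, the size of each step depends on what else the molecule carries, but four compounds do not show why, nor how either change would behave on any further core.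

Going by these compounds, it remains open whether a methoxy group or a nitrile in place of the trifluoromethyl group would show the same dependence. Also open, on these data alone, is whether these steps would hold in other cell lines.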